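Ring-nitrogen substituent series: cycloheptyl step

This account rests on a few compounds, and the source may have more. Where it says the series, first, only, none or still open, it means among the compounds named here.

Compound 2 `Nc1scc(CN2CCN(C3CCCC3)CC2)c1C(=O)c1ccc(Cl)cc1` and compound 1 `Nc1scc(CN2CCN(c3cc(Cl)cc(Cl)c3)CC2)c1C(=O)c1ccc(Cl)cc1` share one core and differ only in the group on the amine nitrogen in the ring. In an assay on CHO cells for displacement of a labelled ligand from adenosine receptor A3 (Homo sapiens), read by scintillation counting, with a stated time of 120 min, tested at 10 uM (on this read-out lower numbers stand for less inhibition and higher numbers for more inhibition at the one concentration tested (going by the name of the read-out)), compound 1 gives 1% and compound 2 gives 3%. Compound 2 stands highest of the two numbers, yet its nearest neighbour is compound 1 and the step of a number 2 percentage points higher from compound 1 to compound 2 (within the scatter) stays within the scatter, so the two cannot be ordered. Compound 3 `Nc1scc(CN2CCN(C3CCCCCC3)CC2)c1C(=O)c1ccc(Cl)cc1` has not yet been measured; it differs from compound 2 by cycloheptyl in place of cyclopentyl on an amine nitrogen in a ring. Within the data shown here, the only step that bears on this change is the one at the same position, from compound 1 to compound 2, and it was flat. With both measured values near the floor of this assay, no step beyond the scatter is expected. The step of a number 1 percentage points higher from compound 2 to compound 3 (within the scatter) is therefore estimated as flat. For compound 3 the expected value in this assay is 4%, within -6% to 14%.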

Compound 3, a percentage reported as inhibition, at one concentration (the size of the read-out at that concentration, not a potency): 0%
Compound 3: middle estimate off by 4 percentage points, on the high side; measured number inside the range.
By their numbers in this assay, from the lowest: compounds 3, 1 and 2 (each within the scatter of the next).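

Cycloheptyl on the amine nitrogen in a ring reads no differently from the two groups before it in this assay: the data show a number 3 percentage points lower from compound 2 to compound 3 (within the scatter) and a number 1 percentage points lower from compound 1 to compound 3 (within the scatter) with no step beyond the scatter in either case. The flat result now holds across a five-membered and a seven-membered non-aromatic ring of carbon only, as well as 3,5-dichlorophenyl, so neither ring size nor the choice of these three groups separates the compounds at this position. No supporting measurement is available to explain these readings.

As far as these compounds go, whether a group carrying hydrogen-bond partners, such as a carboxylic acid or a hydroxyethyl chain, would lift the number at this nitrogen stays open. The compounds shown also leave open whether any change elsewhere on the shared core would move these values off the floor.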